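This account rests on a few compounds, and the source may have more. Where it says the series, first, only, none or still open, it means among the compounds named here.

Compounds measured so far:
Compound 1, `CC[C@H](C)[C@H](N)C(=O)NS(=O)(=O)OC[C@H]1O[C@@H](n2cnc3c(N)ncnc32)[C@H](O)[C@@H]1O`, 5600 nM in a functional assay on PBMC cells (Homo sapiens) for inhibition; on this read-out higher numbers stand for weaker inhibition and lower numbers for stronger inhibition.
Compound 2, `N=C(N)NCCC[C@H](N)C(=O)NS(=O)(=O)OC[C@H]1O[C@@H](n2cnc3c(N)ncnc32)[C@H](O)[C@@H]1O`, 1000 nM in this assay.

Within the data shown here, compound 2 stands with the lowest number of the two in this assay; its only neighbour is compound 1, and the step of a 5.6-fold lower number from compound 1 to compound 2 (0.75 log units; beyond the scatter) lies beyond the scatter. Compound 3, `Nc1ncnc2c1ncn2[C@@H]1O[C@H](COS(=O)(=O)NC(=O)[C@@H]2CSCN2)[C@@H](O)[C@H]1O`, has not yet been measured in this assay. It differs from compound 2 by a group of 5 heavy atoms (3 carbon, 1 nitrogen, 1 sulfur; one five-membered non-aromatic ring with 2 hetero atoms) in place of a group of 9 heavy atoms (5 carbon, 4 nitrogen; no ring), on a carbonyl carbon. Among the measured compounds shown here, the only measured step, from compound 1 to compound 2, changed a group on the saturated chain carbon bound to an amine nitrogen and a carbonyl carbon, whereas the change to compound 3 replaces the whole group on the carbonyl carbon, so that step bears only loosely on it. For the measured compounds named here, with no direct precedent, compound 3 is expected to lose some of the gain seen in compound 2, giving a step of a 3.0-fold higher number from compound 2 to compound 3 (0.48 log units; beyond the scatter), though wide uncertainty remains. Compound 3 is therefore estimated at 3000 nM, within 500 nM to 20000 nM.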

Compound 3, half-maximal inhibitory concentration: 550 nM
The estimate for compound 3 lay 5.5-fold (0.74 log units) above the measured number, within the range that was stated.
By their numbers in this assay, from the lowest: compounds 3 and 2 (each within the scatter of the next); then compound 1.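

In this assay, the group on the carbonyl carbon need not be an open chain: replacing the chain of 9 heavy atoms in compound 2 with the much smaller 1,3-thiazolidin-4-yl ring gives a 1.8-fold lower number from compound 2 to compound 3 (0.26 log units; within the scatter). The ring therefore stays level with the best chain shown so far, despite having fewer heavy atoms and hydrogen-bond donors. It also clearly separates from the group in compound 1, with a 10-fold lower number from compound 1 to compound 3 (1.01 log units; beyond the scatter), and no measurement at hand explains the behaviour of either group.

On these data alone, what a pyrrolidine ring, with carbon in place of the sulfur, would give remains open, and so does the role of the ring nitrogen. As far as these compounds go, it is also open whether a six-membered ring would fit this position equally well.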